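The source may report more compounds than this note shows. Statements on the series, on what has been measured and on what is new or still open speak of the compounds shown alone.

Three compounds share one core and differ only at a benzyl arm and at the nitrogen that carries it. Compound 1 `C/C=C/C(=O)N(Cc1cccc(O)c1)c1cc(OC)c(OC)c(OC)c1` bears a 3-hydroxyphenyl on that arm, and in a functional assay on HCT-116 cells (Homo sapiens) for inhibition, read by MTT assay, with a stated time of 48 h (on this read-out lower numbers stand for stronger inhibition and higher numbers for weaker inhibition), compound 1 gives 6700 nM. Compound 2 `C/C=C/C(=O)N(Cc1ccc(OC)c(N)c1)c1cc(OC)c(OC)c(OC)c1` bears a 3-amino-4-methoxyphenyl instead; in this assay compound 2 gives 300 nM, the lowest of the three numbers, reached by a 22-fold lower number from compound 1 to compound 2 (1.35 log units; beyond the scatter). Compound 3 `COc1ccc(CNc2cc(OC)c(OC)c(OC)c2)cc1N` has hydrogen where compound 2 has the (prop-1-en-1-yl)carbonyl, and in this assay compound 3 gives 8270 nM, a step of a 28-fold higher number from compound 2 to compound 3 (1.44 log units; beyond the scatter). Compound 4 `C/C=C/C(=O)N(Cc1ccc(OC)c(OC)c1)c1cc(OC)c(OC)c(OC)c1` is not yet measured. It differs from compound 2 by methoxy in place of amino on an aromatic carbon. Among the compounds with values here, only the step from compound 1 to compound 2 touches this ring, and that step changed more than the amino alone. The part of that step that belongs to the amino by itself is not shown, and no measured step swaps an amino for a methoxy by itself. Compound 4 is therefore expected to show a modest step of a 2.0-fold higher number from compound 2 to compound 4 (0.30 log units; within the scatter). For compound 4 the estimate in this assay is 600 nM, within 150 nM to 3000 nM.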

Compound 4, half-maximal inhibitory concentration: 32800 nM
Estimate against measurement, compound 4: 55-fold (1.74 log units) below, outside the stated range (above it).
By their numbers in this assay, from the lowest: compound 2; then compounds 1 and 3 (each within the scatter of the next); then compound 4.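

In this assay, replacing the amino with methoxy, with nothing else changed, gives a 110-fold higher number from compound 2 to compound 4 (2.04 log units; beyond the scatter) and shows what the earlier step through the 3-hydroxyphenyl could not: the amino on this aromatic carbon matters by itself. Activity at this position is therefore highly sensitive to the group placed there, even though the incoming methoxy is barely larger and the ring keeps its methoxy group ortho to this carbon. The methoxy counts no hydrogen-bond donor where the amino counts one, but no measurement here explains the size of the step. The compounds shown leave open whether a methylamino, a dimethylamino or an acetamido group on this carbon would keep the low number of compound 2. They also leave open how a hydroxy group would behave here with the neighbouring methoxy in place.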